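Trimming the Pentyloxy Chain of Compound 3

This account rests on a few compounds, and the source may have more. Where it says the series, first, only, none or still open, it means among the compounds named here.

In an ADME assay on BCBL1 cells (Homo sapiens) for cytotoxicity, with a stated time of 7 days (a higher number here means that more compound is tolerated, a lower number that less compound is tolerated), compound 3 `CCCCCOc1nc(N)nc2c1ncn2/C=C1/CC1(CO)CO` gives > 20000 nM, which is a limit. Compound 1 `CN(C)c1nc(N)nc2c1ncn2/C=C1/CC1(CO)CO` gives > 20000 nM, also a limit. Compound 2 `Nc1nc(NCc2ccccc2)c2ncn(/C=C3/CC3(CO)CO)c2n1` gives a true number, 19900 nM. Compound 4 `CCCCOc1nc(N)nc2c1ncn2/C=C1/CC1(CO)CO` differs from compound 3 by hydrogen in place of methyl on a saturated chain carbon, four bonds along the chain from an oxygen on an aromatic ring. The measured steps are a number no higher from compound 1 to compound 2 (the limit leaves the size open), a step that the two limits leave unreadable from compound 1 to compound 3 and a number no lower from compound 2 to compound 3 (the limit leaves the size open), and none of them has a readable size. The expectation therefore rests on this single change and on compound 3 standing at the limit of > 20000 nM in this assay, at which 2 of the 3 values shown sit. The expected step is a number no higher from compound 3 to compound 4 (the limit leaves the size open), with nothing beyond the scatter anticipated. Compound 4 is estimated at 20000 nM, with an expected range of 13000 nM to 30000 nM.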

Compound 4, half-maximal cytotoxic concentration: > 20000 nM
Compound 4: no number, only a limit; the forecaster's own chance of this, stated with the estimate: 75%; the middle value sits exactly at the limit.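

In this assay compound 4 gives > 20000 nM as a limit and not a number. The only direction shown is a number no lower from compound 2 to compound 4 (the limit leaves the size open) and the size of that step and of every other new step cannot be read, so taking methyl off the chain end reveals no measurable change at this place. Butoxy, like pentyloxy and dimethylamino, yields only a limit on the aromatic carbon: the limit of > 20000 nM in this assay, at which 3 of the 4 values shown sit.

As far as these compounds go, how much of compound 3 or compound 4 is tolerated remains open. From the compounds shown here alone, it is also open whether a propoxy chain or a cyclopropylamine on that aromatic carbon would give a true number.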